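This account rests on a few compounds, and the source may have more. Where it says the series, first, only, none or still open, it means among the compounds named here.

Three members of the series have been run in an ADME assay on HEK293 cells (Homo sapiens) for cytotoxicity, read by MTT assay, with a stated time of 48 h; a lower number here means a stronger inhibitor, a higher number a weaker inhibitor. Compound 1 `CN(c1ccc(NC(=O)c2ccc(C(F)(F)F)cc2C(F)(F)F)cc1OCc1cccc(C(F)(F)F)c1)S(C)(=O)=O` reaches only the limit of this assay, at > 500000 nM. Compound 2 `CN(c1ccc(NC(=O)c2ccc(C(F)(F)F)cc2C(F)(F)F)cc1OCc1ccccc1C(F)(F)F)S(C)(=O)=O` likewise stops at a limit, > 500000 nM. Within the data shown here, compound 3 `CN(c1ccc(NC(=O)c2ccc(C(F)(F)F)cc2C(F)(F)F)cc1OCc1cccc(C(F)(F)F)c1)S(=O)(=O)Cc1ccccc1` is the single member that returns a number in this assay, 176000 nM. Of the two steps between measured compounds, an at least 2.8-fold lower number from compound 1 to compound 3 (0.45 log units; beyond the scatter) is readable, whereas a step that the two limits leave unreadable from compound 1 to compound 2 stays unreadable because both of its ends sit at the limit of > 500000 nM in this assay, at which 2 of the 3 values shown sit. Compound 4 `CN(c1ccc(NC(=O)c2ccc(C(F)(F)F)cc2C(F)(F)F)cc1OCc1ccccc1C(F)(F)F)S(=O)(=O)Cc1ccccc1` carries that same change, now on the scaffold of compound 3: 2-(trifluoromethyl)phenyl in place of 3-(trifluoromethyl)phenyl on a saturated chain carbon bound to an oxygen on an aromatic ring. No readable step bears on this change, so the expectation is for a step within the scatter, no change at the digits printed from compound 3 to compound 4 (within the scatter). Compound 4 is therefore estimated at 176000 nM, between 80000 nM and 400000 nM.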

Compound 4, half-maximal inhibitory concentration: > 500000 nM
Compound 4 ended at the assay's limit; the forecaster's own chance of this, stated with the estimate: 30%; middle value at least 2.8-fold (0.45 log units) from the limit.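

In this assay, the change from 3-(trifluoromethyl)phenyl to 2-(trifluoromethyl)phenyl on a saturated chain carbon bound to an oxygen on an aromatic ring now has a readable size: an at least 2.8-fold higher number from compound 3 to compound 4 (0.45 log units; beyond the scatter). Compound 3 remains the only one of the four to return a number, so the lower number linked to phenyl in place of hydrogen on the sulfonyl-bound carbon appears only with 3-(trifluoromethyl)phenyl. The steps from compound 1 to compound 2 and from compound 2 to compound 4 cannot be read, each having both ends at: the limit of > 500000 nM in this assay, at which 3 of the 4 values shown sit.

From the compounds shown here alone, how far compounds 1, 2 and 4 lie past that limit stays open. Also open, going by these compounds, is how an amine or a carboxylic acid in place of trifluoromethyl on that phenyl would read.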